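A few compounds are considered here, and "the series" means these few. Any claim that something is new, unique, unknown or untested is made for them only; others in the source may bear on it.

Measured in an ADME assay on HEK-293T cells (Homo sapiens) for cytotoxicity, read by luminescence and CellTiter-Glo, with a stated time of 24 h; a higher number here means that more compound is tolerated, a lower number that less compound is tolerated:
Compound 1 `CCCNC(=O)C1CCN(C(=O)c2cc3[nH]cnc3n2Cc2ccc(OC)cc2)CC1` gives > 100000 nM, a limit.
Compound 2 `CCCNC(=O)C1CCN(C(=O)c2cccn2Cc2ccc(OC)cc2)CC1` gives > 100000 nM, a limit.
Compound 3 `CCCNC(=O)C1CCN(C(=O)c2cc3sc(-c4ccccc4)cc3n2Cc2ccc(OC)cc2)CC1` gives > 100000 nM, a limit.

Compound 2 stands at a limit and has no number of its own. Within the data shown here, the series so far shows (the limit of > 100000 nM in this assay, at which 3 of the 3 values shown sit), so no measured step is available as a guide. Compound 4 `CCCNC(=O)C1CCN(C(=O)c2cc(Br)cn2Cc2ccc(OC)cc2)CC1` differs from compound 2 by one change, bromo in place of hydrogen on an aromatic carbon. The expectation leans on compound 3, whose reading is also a limit, > 100000 nM. No change beyond the scatter is expected, and the estimated step is a number no higher from compound 2 to compound 4 (the limit leaves the size open). For compound 4 the estimated value is 100000 nM, with an expected range from 50000 nM to 200000 nM.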

Compound 4, half-maximal cytotoxic concentration: 55000 nM
Compound 4: the middle estimate sits 1.8-fold (0.26 log units) above what was measured; the range from low to high includes it.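

In this assay, among these compounds, compound 4 gives the first reading of the series that is a number and not a limit, 55000 nM. Bromo in place of hydrogen on this aromatic carbon, two ring bonds from the ring nitrogen, gives an at least 1.8-fold lower number from compound 2 to compound 4 (0.25 log units; that floor lies within the scatter). The true size of the step stays open, with compound 2 at a limit: the limit of > 100000 nM in this assay, at which 3 of the 4 values shown sit.

The compounds shown leave open whether chloro, an amine or a carboxylic acid on this same carbon would also bring the reading off the limit.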